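From 4-chlorophenyl to 2-methoxyphenyl on a shared core

The compounds below may be only part of what the source reports. "The series", "measured", "known", "first", "only" and "open" are said of these compounds alone.

Measured so far in a functional assay (muscle tissue) with Cavia porcellus as the target; a lower number here means that less compound is needed, a higher number that more compound is needed for the effect:
- compound 1 `COC(=O)C1=C(C)N=C(C)/C(=C(\O)OC)C1c1ccc(Cl)cc1` gives 8130 nM
- compound 2 `COC(=O)C1=C(C)N=C(C)/C(=C(\O)OC)C1c1cccc(N(C)C)c1` gives 891 nM

Compound 1 stands highest of the two numbers, and compound 2 lies well under it, a gap beyond the usual scatter. These two values show that the number can differ widely between compounds built on this shared core.

Compound 3 `COC(=O)C1=C(C)N=C(C)/C(=C(\O)OC)C1c1ccccc1OC` keeps that core and carries 2-methoxyphenyl in place of 4-chlorophenyl on a saturated ring carbon. Going by the values given here, no measured step isolates this exchange, so any expectation for it remains loose. Compound 1 (8130 nM) holds the higher value and compound 2 (891 nM) already lies far lower, so a clear drop in this assay is expected for compound 3, beyond the scatter. The expected step is a 54-fold lower number from compound 1 to compound 3 (1.73 log units; beyond the scatter), an estimate with a wide margin. Compound 3 is estimated at 150 nM, with an expected range from 20 nM at the lower end to 1200 nM at the upper end.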

Compound 3, half-maximal effective concentration: 57.5 nM
For compound 3 the middle estimate is 2.6-fold (0.42 log units) above the measured one, and the stated range covers the measured number.
By their numbers in this assay, from the lowest: compound 3; then compound 2; then compound 1.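

In this assay the exchange of 4-chlorophenyl for 2-methoxyphenyl on the saturated ring carbon gives a 140-fold lower number from compound 1 to compound 3 (2.15 log units; beyond the scatter), so this one position, three ring bonds from the ring nitrogen, can carry a large change on its own while the rest of the shared core stays fixed. Compound 1 and compound 2 alone showed only that the number can differ widely on this core, whereas compound 3 at 57.5 nM also lies under compound 2 at 891 nM, which places 2-methoxyphenyl lowest among the three groups shown at this position. Nothing available gives a reason for the size of this step.

Because the exchange alters both the group on the phenyl ring and its place on that ring, the compounds shown do not separate the two, and 2-chlorophenyl or 4-methoxyphenyl at this position would be needed to tell them apart. Going by these compounds, whether a nitro group or a longer alkoxy chain on the phenyl ring would go lower still, or whether the number would rise again, also remains open.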